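Capping a hydroxy group on the saturated-chain compound

A few compounds are considered here, and "the series" means these few. Any claim that something is new, unique, unknown or untested is made for them only; others in the source may bear on it.

In a functional assay on MDA-MB-231 cells (Homo sapiens) for antiproliferative activity, read by MTT assay (on this read-out lower numbers stand for stronger inhibition and higher numbers for weaker inhibition), compound 3 `CCCCCCCCCCCCCCCc1cc(=O)c2c(O)cc(O)c(C)c2o1` gives 6790 nM. Compound 1 `CCCC/C=C\CCCCCCCCCc1cc(=O)c2c(O)cc(O)c(C)c2o1`, which carries a double bond in its long chain, gives 6790 nM. The two stand level: no change at the digits printed from compound 1 to compound 3 (within the scatter). Compound 4 `CCCCCCCCCCCCCCCc1cc(=O)c2c(O)cc(OCOC)c(C)c2o1` differs from compound 3 in one place: methoxymethyl in place of hydrogen on an oxygen on an aromatic ring. Put simply, a hydroxy becomes a methoxymethoxy, with methoxymethyl in place of hydrogen on an oxygen on an aromatic ring. The same swap has one precedent, which leads from compound 1 to compound 2 `CCCC/C=C\CCCCCCCCCc1cc(=O)c2c(O)cc(OCOC)c(C)c2o1`. Compound 2 gives > 87000 nM, which is a limit of the assay and not a number. That swap was a large step: an at least 12-fold higher number from compound 1 to compound 2 (1.10 log units; beyond the scatter). The chain difference left the values level, so a similar large step is expected here, although the expectation rests on this single pair. The expected step in this assay, toward weaker inhibition, is a 14-fold higher number from compound 3 to compound 4 (1.15 log units; beyond the scatter). Compound 4 is estimated at 95000 nM, with an expected range of 35000 nM to 250000 nM, and the assay may well report only a limit.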

Compound 4, half-maximal inhibitory concentration: > 87000 nM
Compound 4: a limit, no number; the forecaster's own chance of this, stated with the estimate: 70%; the middle value does not contradict the limit.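

In this assay, the large loss of activity seen on the chain with the double bond returns on the saturated chain, with an at least 12-fold higher number from compound 3 to compound 4 (1.10 log units; beyond the scatter). This step rests on a limit of the assay for compound 4 and not on a number. The effect of replacing the hydrogen on this oxygen with methoxymethyl therefore no longer depends on a single pair, and it appears with either chain: the same change on two cores in this assay, an at least 12-fold higher number (1.10 log units; beyond the scatter) from compound 1 to compound 2 and an at least 12-fold higher number (1.10 log units; beyond the scatter) from compound 3 to compound 4; the limit leaves it open whether they differ

From the compounds shown here alone, compound 2 and compound 4 both stop at a limit, so the step between them cannot be read, and the true size of both losses and any effect of the double bond on the capped compounds stay hidden: the limit of > 87000 nM in this assay, at which 2 of the 4 values shown sit. It also remains open whether a plain methyl or an acetyl on this oxygen would cost as much activity as methoxymethyl.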